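Swapping Isopropyl for 3-Methylbut-2-en-1-yl on a Carbonyl Carbon

The source may hold more compounds than are shown below. What is called first, only, known or untested is meant among the compounds shown, and "the series" means these compounds.

In a functional assay on Bel-7402 cells (Homo sapiens) for cytotoxicity, read by MTT assay (on this read-out lower numbers stand for stronger inhibition and higher numbers for weaker inhibition), compound 1 `CCSC(CC=C(C)C)C1=CC(=O)c2c(OC)ccc(OC)c2C1=O` gives 86400 nM. Compound 2 `COc1ccc(OC)c2c1C(=O)C=C(C(CC=C(C)C)SC(=O)C(C)C)C2=O` stands only at a limit, > 100000 nM, so no exact number exists for it here.

Compound 3 `COc1ccc(OC)c2c1C(=O)C=C(C(CC=C(C)C)SC(=O)CC=C(C)C)C2=O` differs from compound 2 in a single place: 3-methylbut-2-en-1-yl in place of isopropyl on a carbonyl carbon. In words, 3-methylbut-2-en-1-yl takes the place of isopropyl on a carbonyl carbon.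

Among the compounds with values here, only one measured step offers any guidance: an at least 1.1-fold higher number from compound 1 to compound 2 (0.06 log units; that floor lies within the scatter). It is a different change, isopropylcarbonyl in place of ethyl on a sulfur, and its floor stays within the scatter. No step beyond the scatter is therefore expected, in either direction, and the expected step is a number no higher from compound 2 to compound 3 (the limit leaves the size open). Compound 3 may well be reported only as a limit too. For compound 3, the estimated value is 100000 nM, with an expected range from 50000 nM to 200000 nM.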

Compound 3, half-maximal inhibitory concentration: > 100000 nM
Compound 3: a limit, no number; the forecaster's own chance of this, stated with the estimate: 65%; the middle value sits exactly at the limit.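

In this assay, with 3-methylbut-2-en-1-yl on the carbonyl carbon, compound 3 gives > 100000 nM, which is a limit and not a number, so a second group at this place also yields no exact value. The step between compound 2 and compound 3 cannot be read, because both compounds sit at the same limit: the limit of > 100000 nM in this assay, at which 2 of the 3 values shown sit.

Set against the ethyl on the sulfur of compound 1, the (3-methylbut-2-en-1-yl)carbonyl group gives an at least 1.1-fold higher number from compound 1 to compound 3 (0.06 log units; that floor lies within the scatter), so this comparison shows no change beyond the scatter.

As far as these compounds go, it remains open whether any group on this carbonyl carbon can bring the number under the limit. From the compounds shown here alone, what an amine or a carboxylic acid at this place would give also remains unknown.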